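Chloro for Fluoro in Two Paired Sulfonamides

The source may hold more compounds than are shown below. What is called first, only, known or untested is meant among the compounds shown, and "the series" means these compounds.

Compound 1, `Cc1ccc(S(=O)(=O)Nc2ccc(Cl)cc2)cc1`, in an ADME assay, gives 9.02.
Compound 2, `Cc1ccc(S(=O)(=O)Nc2ccc(F)cc2)cc1`, in this assay gives 9.2.
Compound 3, `Cc1ccc(NS(=O)(=O)c2ccc(F)cc2)cc1`, in this assay gives 9.23.

Compound 2 and compound 1 share a core and differ by one change, (chloro in place of fluoro on an aromatic carbon), which made a step of a number 0.18 log units lower from compound 2 to compound 1 (within the scatter). Compound 3 and compound 2 have the same atoms joined differently; how the two cores differ is not broken down here. Compound 4, `Cc1ccc(NS(=O)(=O)c2ccc(Cl)cc2)cc1`, has not been measured; it stands to compound 3 as compound 1 stands to compound 2, through (chloro in place of fluoro on an aromatic carbon), at a place described in the same words as before, so the change is the same. The step expected from compound 3 to compound 4 in this assay is a number 0.18 log units lower from compound 3 to compound 4 (within the scatter), resting on the measured step of a number 0.18 log units lower from compound 2 to compound 1 (within the scatter). Compound 4 is therefore estimated at 9.05, with a likely range from 8.8 to 9.3.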

Compound 4, acid dissociation constant: 8.78
Beside the measured number, compound 4's estimate is 0.27 log units above it, outside the stated range (below it).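

In this assay, chloro in place of fluoro on an aromatic carbon makes a step of a number 0.45 log units lower from compound 3 to compound 4 (beyond the scatter). Set beside the earlier step, the change does not read differently on the two cores: the same change on two cores in this assay, a number 0.18 log units lower (within the scatter) from compound 2 to compound 1 and a number 0.45 log units lower (beyond the scatter) from compound 3 to compound 4, 0.27 log units apart, within the scatter of two such steps. Among the compounds shown here, this shows that, within the scatter, the step carries from one of these cores to the other, but it rests on only two pairs and does not show that the step has one fixed size or that it would hold on any further core.

The compounds shown leave open how this assay responds when a nitrile or a methoxy group stands in the place of chloro or fluoro. They also leave open whether the step persists on a core carrying an amine or a longer chain.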